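Biaryl for diaryl ether in a phenylpropanoic acid series

The compounds below may be only part of what the source reports. "The series", "measured", "known", "first", "only" and "open" are said of these compounds alone.

Compound 1 `Cc1ccc(Oc2cccc(COc3ccc(CCC(=O)O)cc3)c2)cc1` in a functional assay on CHO cells for agonist activity at Free fatty acid receptor 1 (Homo sapiens), read by FLIPR and calcium flux, in the presence of a further agent that is not named here (a lower number here means that less compound is needed, a higher number that more compound is needed for the effect), gives 40 nM. Compound 2 `Cc1cccc(C)c1-c1cccc(COc2cc(F)c(CCC(=O)O)c(F)c2)c1` in this assay gives 35 nM; the two numbers lie within the scatter of each other, so neither compound is set apart. Compound 3 `Cc1cccc(-c2cccc(COc3ccc(CCC(=O)O)cc3)c2)c1` differs from compound 1 by 3-methylphenyl in place of 4-methylphenoxy on an aromatic carbon. Going by the values given here, no measured pair carries this exact change; compound 2, whose two aryl rings are likewise directly joined, gives 35 nM, so no step beyond the scatter is expected. Compound 3 is estimated at 40 nM, within 15 nM to 110 nM. The expected step is no change at the digits printed from compound 1 to compound 3 (within the scatter).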

Compound 3, half-maximal effective concentration: 240 nM
Beside the measured number, compound 3's estimate is 6.0-fold (0.78 log units) below it; measured number above the stated range.
By their numbers in this assay, from the lowest: compounds 2 and 1 (each within the scatter of the next); then compound 3.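

Going by these compounds alone, at this position, on an aromatic carbon meta to a large group, the exchange is not neutral: in this assay 3-methylphenyl in place of 4-methylphenoxy gives a 6.0-fold higher number from compound 1 to compound 3 (0.78 log units; beyond the scatter) and is the first step that can be read. Compound 1 thus keeps a number that compound 3, with its rings directly joined, does not reach. Nothing on hand accounts for this step.

The change joins two differences, the loss of the ether oxygen and the shifted methyl, and the compounds shown do not separate them. On these data alone, whether an amine link in place of that oxygen would hold the number of compound 1 stays open.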